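Ring size of the amine on the benzylic carbon: compound 4

The compounds below may be only part of what the source reports. "The series", "measured", "known", "first", "only" and "open" are said of these compounds alone.

Measured so far:
compound 1 `COc1cc2c(cc1OC)C(=O)/C(=C/c1ccc(CN(C)C)c(O)c1)CO2` 8.2%
compound 2 `CCN(CC)Cc1ccc(/C=C2\COc3cc(OC)c(OC)cc3C2=O)cc1O` 9.5%
compound 3 `COc1cc2c(cc1OC)C(=O)/C(=C/c1ccc(CN3CCCC3)c(O)c1)CO2` 16.4%

In an assay on isolated protein for inhibition of Amine oxidase [flavin-containing] A (Homo sapiens), read by fluorescence, with a stated time of 30 min, tested at 20 uM (a lower number here means less inhibition, a higher number more inhibition at the concentration tested (going by the name of the read-out)), compound 3 gives the highest of the three numbers, yet every step to it lies within the scatter: a number 8.2 percentage points higher from compound 1 to compound 3 (within the scatter) and a number 6.9 percentage points higher from compound 2 to compound 3 (within the scatter), as does a number 1.3 percentage points higher from compound 1 to compound 2 (within the scatter). The three amines shown therefore read as one level.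

Compound 4 `COc1cc2c(cc1OC)C(=O)/C(=C/c1ccc(CN3CCCCC3)c(O)c1)CO2` continues the ring series: piperidin-1-yl in place of pyrrolidin-1-yl on a saturated chain carbon bound to an aromatic carbon. All three measured steps bear on this change and none moved beyond the scatter, so no step beyond the scatter is expected in this assay for compound 4 either; the expected step is a number 1.4 percentage points lower from compound 3 to compound 4 (within the scatter). Compound 4 is estimated at 15%, within a range of 4% to 28%.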

Compound 4, a percentage reported as inhibition, at one concentration (the size of the read-out at that concentration, not a potency): 24.6%
The estimate for compound 4 lay 9.6 percentage points below the measured number; measured number inside the range.
By their numbers in this assay, from the lowest: compounds 1, 2, 3 and 4 (each within the scatter of the next, the first and the last beyond it).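

In this assay, going by these compounds alone, the piperidin-1-yl amine on this saturated chain carbon is the first to separate from the open-chain amines, with a number 15.1 percentage points higher from compound 2 to compound 4 (beyond the scatter) and a number 16.4 percentage points higher from compound 1 to compound 4 (beyond the scatter) both modest. Pyrrolidin-1-yl does not separate from them, and a number 8.2 percentage points higher from compound 3 to compound 4 (within the scatter) leaves the two ring amines unresolved, so a ring alone does not account for the separation. Nothing on hand gives a reason for this difference. Still open, from the compounds shown here alone, is whether azepan-1-yl, morpholin-4-yl or 4-methylpiperazin-1-yl at this place would match piperidin-1-yl.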